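Returning an Aryl Group to the Ring Nitrogen

The compounds below may be only part of what the source reports. "The series", "measured", "known", "first", "only" and "open" are said of these compounds alone.

Compound 1: `CCOC(=O)C1=Cc2ccccc2OC1(OCc1cn(-c2ccc(C)cc2)nn1)C(F)(F)F`, 19700 nM
Compound 2: `CCOC(=O)C1=Cc2ccccc2OC1(OCc1cn(CC(=O)Nc2ccccc2F)nn1)C(F)(F)F`, 50100 nM
Compound 3: `CCOC(=O)C1=Cc2ccccc2OC1(OCc1cn(-c2cccc(C(F)(F)F)c2)nn1)C(F)(F)F`, not yet measured

In a functional assay on A549 cells (Homo sapiens) for inhibition, read by MTT assay, with a stated time of 24 h (a lower number here means a stronger inhibitor, a higher number a weaker inhibitor), compound 1 gives 19700 nM, while compound 2 gives 50100 nM. Compound 2 thus has the highest number of the two measured compounds, with compound 1 as its nearest neighbour: a 2.5-fold higher number from compound 1 to compound 2 (0.41 log units; beyond the scatter), a modest step. Compound 3 differs from compound 2 in one place: 3-(trifluoromethyl)phenyl in place of ((2-fluorophenyl)carbamoyl)methyl on an aromatic nitrogen. Within the data shown here, the only measured step that bears on this change is the one from compound 1 to compound 2, in which a directly attached aryl group gave way to the amide-bearing arm. Compound 3 undoes that kind of change, putting an aryl group back on the ring nitrogen, though 3-(trifluoromethyl)phenyl rather than 4-methylphenyl. A shift toward stronger inhibition of about that size is therefore expected, namely a 2.3-fold lower number from compound 2 to compound 3 (0.36 log units; beyond the scatter). For compound 3 the estimated value is 22000 nM, within a range of 8000 nM to 60000 nM.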

Compound 3, half-maximal inhibitory concentration: > 150000 nM
Compound 3: no number, only a limit (the forecaster's own chance of this, stated with the estimate: 10%); middle value at least 6.8-fold (0.83 log units) from the limit.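

In this assay, compound 3 gives only a limit of the assay, not an exact number: the limit of > 150000 nM in this assay, at which 1 of the 3 values shown sits. Even so, the limit shows an at least 2.9-fold higher number from compound 2 to compound 3 (0.47 log units; beyond the scatter), so placing an aryl group directly on the ring nitrogen does not by itself restore the value of compound 1. The change between the two aryl groups gives an at least 7.6-fold higher number from compound 1 to compound 3 (0.88 log units; beyond the scatter), so the number at this position depends on which aryl group is attached, not only on whether one is there.

With just two directly attached aryl groups, the compounds shown cannot separate the effect of the group's identity from that of its place on the phenyl ring. From the compounds shown here alone, whether an unsubstituted phenyl group on the same nitrogen would fall nearer compound 1 or compound 3 also remains open.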